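The source may hold more compounds than are shown below. What is called first, only, known or untested is meant among the compounds shown, and "the series" means these compounds.

Compound 1 `Cc1nn(C)c2nc(NNC(=O)Nc3cc(Cl)nc(Cl)c3)cc(-c3ccc(Cl)s3)c12` and compound 2 `Cc1nn(C)c2nc(NNC(=O)Nc3cc(Cl)nc(Cl)c3)cc(-c3ccc(F)cc3)c12` share one core and differ only in the aromatic group attached to it. In a functional assay on HCT-116 cells (Homo sapiens) for cytotoxicity, read by MTT assay, with a stated time of 48 h, in the presence of a further agent that is not named here (a lower number here means that less compound is needed, a higher number that more compound is needed for the effect), compound 1 gives 42100 nM, and compound 2 gives 25200 nM. Compound 2 thus holds the lower of the two numbers, but the gap is a 1.7-fold lower number from compound 1 to compound 2 (0.22 log units; within the scatter). Compound 3 `Cc1nn(C)c2nc(NNC(=O)Nc3cc(Cl)nc(Cl)c3)cc(-c3ccco3)c12` differs from compound 2 by furan-2-yl in place of 4-fluorophenyl on an aromatic carbon. Among the compounds with values here, the only step measured at this position stayed within the scatter, so no step beyond the scatter is expected from this change in this assay. The expected step is a 1.1-fold higher number from compound 2 to compound 3 (0.05 log units; within the scatter). Compound 3 is therefore estimated at 28000 nM, within a range of 9000 nM to 90000 nM.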

Compound 3, half-maximal effective concentration: 69200 nM
Compound 3: the middle estimate sits 2.5-fold (0.39 log units) below what was measured, within the range that was stated.
By their numbers in this assay, from the lowest: compounds 2, 1 and 3 (each within the scatter of the next, the first and the last beyond it).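

Within the data shown here, this position is not indifferent to the group it carries: furan-2-yl in place of 4-fluorophenyl gives the first step here beyond the scatter, though a modest one, with a 2.7-fold higher number from compound 2 to compound 3 (0.44 log units; beyond the scatter). Furan-2-yl in place of 5-chlorothiophen-2-yl stays within the scatter, with a 1.6-fold higher number from compound 1 to compound 3 (0.22 log units; within the scatter). No measurement at hand explains why these two swaps differ. Going by these compounds, all three groups are single aromatic rings, so it remains open how an amine, a carboxylic acid or a longer alkyl chain would behave at this position.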